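Two Chlorines on the Aniline Ring of a Bridged Diamine

A few compounds are considered here, and "the series" means these few. Any claim that something is new, unique, unknown or untested is made for them only; others in the source may bear on it.

The compounds measured so far:
compound 1, `Clc1ccc(Nc2ccc(N3CC4CC(C3)N4)cn2)cc1`, 2.49 nM
compound 2, `c1ccc(Nc2ccc(N3CC4CC(C3)N4)cn2)cc1`, 2.66 nM
compound 3, `Clc1ccc(Nc2cncc(N3CC4CC(C3)N4)c2)cc1`, 0.118 nM

All three were tested in an assay on cell membranes for displacement of a labelled ligand from Neuronal acetylcholine receptor; alpha4/beta2 (Rattus norvegicus); a lower number here means a stronger inhibitor, a higher number a weaker inhibitor. Compound 1 and compound 2 share a core and differ only by chloro in place of hydrogen on an aromatic carbon; this gave a 1.1-fold lower number from compound 2 to compound 1 (0.03 log units; within the scatter). Compound 3 carries the same chloro group as compound 1 but a different core; how the two cores differ is not broken down here. In this assay compound 3 gives the lowest number of the three, and compound 1 and compound 2 give numbers that stand well above it.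

Compound 4, `Clc1ccc(Nc2cncc(N3CC4CC(C3)N4)c2)cc1Cl`, has not been measured. It differs from compound 3 by chloro in place of hydrogen on an aromatic carbon. Among the compounds with values here, this is the same kind of change as the one from compound 2 to compound 1, but the surroundings differ: in the earlier pair the new chloro sat para to a large group, whereas here it sits ortho to a chloro group and meta to a large group.

The expectation for compound 4 rests on a single earlier step, a 1.1-fold lower number from compound 2 to compound 1 (0.03 log units; within the scatter), which lay within the scatter. On that basis the step from compound 3 to compound 4 is estimated at a 1.3-fold higher number from compound 3 to compound 4 (0.10 log units; within the scatter). Compound 4 is therefore expected to give about 0.15 nM in this assay, with a plausible range from 0.05 nM to 0.5 nM.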

Compound 4, inhibition constant: 1.25 nM
Compound 4: middle estimate off by 8.3-fold (0.92 log units), on the low side, outside the stated range (above it).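

In this assay, chloro in place of hydrogen on an aromatic carbon gave an 11-fold higher number from compound 3 to compound 4 (1.03 log units; beyond the scatter), so the added chloro came with a clearly weaker inhibitor on this core. The same kind of change therefore did not carry over unchanged from one core to the other: the same change on two cores in this assay, a 1.1-fold lower number (0.03 log units; within the scatter) from compound 2 to compound 1 and an 11-fold higher number (1.03 log units; beyond the scatter) from compound 3 to compound 4, 11-fold (1.05 log units) apart, beyond the scatter of two such steps

This shows that the step seen on the core of compound 1 was a poor guide to the step on the core of compound 3, but it does not show why the two steps part, or that the core alone is responsible. The new chloro in compound 4 sits ortho to a chloro group and meta to a large group, a different place from the new chloro in compound 1, and a single pair on each core cannot separate the place of the group from the core that carries it.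

The compounds shown leave open what a second chloro in this same place would do on the core of compound 1, which would keep the place fixed while the core changes. They also leave open whether a smaller fluoro, a methyl or an amine in that place would give a number closer to that of compound 3 or to that of compound 4.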